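This account rests on a few compounds, and the source may have more. Where it says the series, first, only, none or still open, it means among the compounds named here.

Of the compounds shown here, three have been measured in a functional assay on PC-3 cells (Homo sapiens) for antiproliferative activity, read by MTT assay, with a stated time of 48 h; on this read-out lower numbers stand for stronger inhibition and higher numbers for weaker inhibition: compound 1 `COc1cc(/C=C/C(C)=O)ccc1OCc1cn(-c2ccc(/N=N/c3ccccc3)cc2)nn1` gives 42100 nM, compound 2 `COc1cc(/C=C/C(C)=O)ccc1OCc1cn(-c2ccccc2OC)nn1` gives 2050 nM, and compound 3 `COc1cc(/C=C/C(C)=O)ccc1OCc1cn(-c2ccc([N+](=O)[O-])cc2)nn1` gives 46700 nM.

Compound 1 stands second highest of the three. Its nearest neighbour is compound 3 (a 1.1-fold higher number from compound 1 to compound 3 (0.05 log units; within the scatter)); its furthest is compound 2, whose number is much lower. Compound 4 `COc1cc(/C=C/C(C)=O)ccc1OCc1cn(-c2ccccc2)nn1` differs from compound 1 as follows: a hydrogen atom in place of a group of 8 heavy atoms (6 carbon, 2 nitrogen; one six-membered aromatic ring of carbon only), on an aromatic carbon. Among the compounds with values here, two measured steps bear on this. The first, a 1.1-fold higher number from compound 1 to compound 3 (0.05 log units; within the scatter), shows that exchanging the group on the aromatic carbon left the number where it was. The second, a 23-fold higher number from compound 2 to compound 3 (1.36 log units; beyond the scatter), shows that the group on the aromatic nitrogen can shift the number greatly. Compound 4 removes the large group rather than exchanging it, so a modest lowering is expected, a 2.1-fold lower number from compound 1 to compound 4 (0.32 log units; beyond the scatter). Compound 4 is expected to give 20000 nM, within 6000 nM to 60000 nM.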

Compound 4, half-maximal inhibitory concentration: 78600 nM
Beside the measured number, compound 4's estimate is 3.9-fold (0.59 log units) below it; measured number above the stated range.
By their numbers in this assay, from the lowest: compound 2; then compounds 1, 3 and 4 (each within the scatter of the next).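

In this assay, taking the large group off this aromatic carbon altogether leaves the number within the scatter, a 1.9-fold higher number from compound 1 to compound 4 (0.27 log units; within the scatter), and hydrogen in place of nitro does the same, a 1.7-fold higher number from compound 3 to compound 4 (0.23 log units; within the scatter), so hydrogen, nitro and the large group cannot be told apart here. Only methoxy stands apart, a 38-fold higher number from compound 2 to compound 4 (1.58 log units; beyond the scatter). Nothing measured accounts for this.

As far as these compounds go, whether the lower number of compound 2 goes with methoxy itself or with where it sits stays open. So does whether an amine or a carboxylic acid on this carbon would move the number.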